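Removing one methoxy group from a trimethoxyphenyl pyrazole chalcone

The compounds below may be only part of what the source reports. "The series", "measured", "known", "first", "only" and "open" are said of these compounds alone.

The account concerns three measured compounds and one that awaits measurement. Compound 1 `COc1cc(-c2cc(/C=C/C(=O)c3ccc(N)cc3)[nH]n2)cc(OC)c1OC` was tested in a functional assay on Malme-3M cells (Homo sapiens) for inhibition, read by sulforhodamine B assay, with a stated time of 48 h (a higher number here means a weaker inhibitor of growth, a lower number a stronger inhibitor of growth), and gave 2050 nM. Compound 2 `COc1ccc(C(=O)/C=C/c2cc(-c3cc(OC)c(OC)c(OC)c3)n[nH]2)cc1OC` differs from compound 1 in its core, a difference counted as 4-aminophenyl in place of 3,4-dimethoxyphenyl on a carbonyl carbon; in this assay compound 2 gave 1990 nM, so that a 1.0-fold lower number from compound 1 to compound 2 (0.01 log units; within the scatter) was observed. Compound 3 `COc1ccc(C(=O)/C=C/c2cc(-c3cc(OC)c(OC)c(OC)c3)n[nH]2)cc1` arises from compound 2 by hydrogen in place of methoxy on an aromatic carbon, and in this assay compound 3 gave 1860 nM, which makes a 1.1-fold lower number from compound 2 to compound 3 (0.03 log units; within the scatter).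

Compound 4 `COc1ccc(-c2cc(/C=C/C(=O)c3ccc(N)cc3)[nH]n2)cc1OC` arises from compound 1 by hydrogen in place of methoxy on an aromatic carbon. For the measured compounds named here, this is the same kind of change as the one from compound 2 to compound 3, though not the same: around the place in compound 1 the carbon is also meta to a methoxy group (2 heavy atoms), whereas in compound 2 it is ortho to a methoxy group (2 heavy atoms) and meta to a large group only. Because a 1.1-fold lower number from compound 2 to compound 3 (0.03 log units; within the scatter) stayed within the scatter, the expectation for compound 4 is that the change from compound 1 should likewise barely move the number, so the estimated step is a 1.1-fold lower number from compound 1 to compound 4 (0.03 log units; within the scatter). Accordingly, compound 4 is expected to give about 1900 nM in this assay, with a plausible range from 900 nM to 4000 nM.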

Compound 4, concentration for 50% growth inhibition: 6720 nM
Compound 4: the middle estimate sits 3.5-fold (0.55 log units) below what was measured; the whole stated range lies below it.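

In this assay, replacing the methoxy group with hydrogen on the core of compound 1 gave a 3.3-fold higher number from compound 1 to compound 4 (0.52 log units; beyond the scatter), a step beyond the scatter, whereas the same kind of change on the core of compound 2 stayed within it. The change therefore cannot be carried from one core to the other in this series as a fixed step: the same change on two cores in this assay, a 1.1-fold lower number (0.03 log units; within the scatter) from compound 2 to compound 3 and a 3.3-fold higher number (0.52 log units; beyond the scatter) from compound 1 to compound 4, 3.5-fold (0.54 log units) apart, beyond the scatter of two such steps

This rests on one pair for each core in a single cell assay, and the two pairs differ both in the rest of the core and in the surroundings of the place, since only in compound 1 is the carbon also meta to a methoxy group, so it shows that the step does not transfer but not which of these differences is responsible.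

The compounds shown leave open whether the larger step belongs to that further methoxy group or to the 4-aminophenyl on the carbonyl carbon, a question that a pair on a single core differing only in one of these features could address. They also leave open how a hydroxy group or an ethoxy group at the same place on the core of compound 1 would read.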